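Removing the Carbamate from Compound 2

The source may hold more compounds than are shown below. What is called first, only, known or untested is meant among the compounds shown, and "the series" means these compounds.

Of the compounds shown here, three built on one shared core have so far been measured in an assay on isolated protein (Cricetulus griseus) for binding affinity to Alpha-1B adrenergic receptor (Mesocricetus auratus), read by radioligand binding; on this read-out higher numbers stand for weaker inhibition and lower numbers for stronger inhibition. Compound 1 `CS(=O)(=O)Nc1ccc(Cl)c2c1CCCC2c1c[nH]cn1` gives < 10000 nM, which is a limit of the assay rather than a number. Compound 3 `Cn1cnc(C2CCCc3c(NS(C)(=O)=O)cccc32)c1` gives 2040 nM. Compound 2 `COC(=O)Nc1cccc2c1CCCC2c1c[nH]cn1` gives 10000 nM, the higher of the two numbers reported, and the gap between compound 2 and compound 3 lies beyond the usual scatter of repeated measurements.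

Compound 4 `Nc1cccc2c1CCCC2c1c[nH]cn1` has not yet been measured. It differs from compound 2 in a single place: hydrogen in place of methoxycarbonyl on a nitrogen on an aromatic ring. Among the measured compounds shown here, no pair of measured compounds shows this same change, so the size of the step cannot be read off from the data and has to be guessed. The expectation is a modest step, a 1.7-fold lower number from compound 2 to compound 4 (0.22 log units; within the scatter), toward a somewhat lower number, since compound 2 sits at 10000 nM while compound 3, bearing a different group on the same nitrogen, sits at 2040 nM, which suggests the core tolerates variation at that position without dropping out of range. Compound 4 is therefore estimated at 6000 nM, with a plausible range from 1500 nM to 30000 nM.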

Compound 4, inhibition constant: 525 nM
For compound 4 the middle estimate is 11-fold (1.06 log units) above the measured one; measured number outside the range, below it.
By their numbers in this assay, from the lowest: compound 4; then compound 3; then compound 2.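

In this assay, the change on this aromatic nitrogen gives a 19-fold lower number from compound 2 to compound 4 (1.28 log units; beyond the scatter), a large step well beyond the scatter. Among the compounds shown here, the earlier compounds offered no pair differing in one place, so this is the first direct reading of the position, and it shows that what the nitrogen carries strongly shifts the number, with the plain amino group standing far lower than the (methoxycarbonyl)amino group. The size of the step carries one caution, as the number at its upper end stands at the same figure as a limit of the assay: the limit of < 10000 nM in this assay, at which 1 of the 4 values shown sits.

The compounds shown leave open whether the lower number comes from the free amino group itself or simply from the loss of the methoxycarbonyl, as no other group on this nitrogen can be compared in one place. Going by these compounds, a single methyl group or an acetyl group on that nitrogen would separate these two readings, and whether the same change holds on the other variants of the shared core also remains unknown.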